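A Carboxy-Hydroxyphenyl Group Replacing a Halogenated Phenyl

The compounds below may be only part of what the source reports. "The series", "measured", "known", "first", "only" and "open" are said of these compounds alone.

Measured compounds:
compound 1, `O=C1c2ccc(OCc3cccc(-c4ccc(Cl)cc4F)c3)cc2CN1C1CCCC1`, > 5000 nM
compound 2, `O=C(O)c1cc(-c2cccc(COc3ccc4c(=O)n(CC5CC5)sc4c3)c2)ccc1Cl`, 2480 nM
compound 3, `CN(C)C(=O)c1cc(-c2cccc(COc3ccc4c(=O)n(C5CCCC5)sc4c3)c2)ccc1Cl`, 980 nM

In an assay on HEK293 cells for positive allosteric modulation of metabotropic glutamate receptor 2 (Rattus norvegicus), read by thallium flux (on this read-out higher numbers stand for an effect only at larger amounts of compound and lower numbers for an effect already at smaller amounts), compound 1 gives only a limit, > 5000 nM; one of the three values sits there (the limit of > 5000 nM in this assay, at which 1 of the 3 values shown sits), so no number is known for it, only an edge. Compound 2 and compound 3 are built on a core different from that of compound 1, and in this assay compound 2 gives 2480 nM while compound 3 gives 980 nM.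

The unmeasured compound 4, `O=C(O)c1cc(-c2cccc(COc3ccc4c(c3)CN(C3CCCC3)C4=O)c2)ccc1O`, keeps the core of compound 1 and changes one place: 3-carboxy-4-hydroxyphenyl in place of 4-chloro-2-fluorophenyl on an aromatic carbon. In words, 3-carboxy-4-hydroxyphenyl in place of 4-chloro-2-fluorophenyl on an aromatic carbon. Among the measured compounds shown here, no step between two measured compounds matches this change, so the size of the step is open. For the measured compounds named here, the only guidance is that compound 2, which also carries a carboxy group on its outer ring, gives 2480 nM, a number rather than a limit. On that basis a move from the limit of compound 1 toward an effect at smaller amounts is expected, but a wide spread is kept. Compound 4 is expected to give 3000 nM, with an estimated range from 800 nM to 15000 nM. This estimate corresponds to an expected step of an at least 1.6-fold lower number from compound 1 to compound 4 (0.22 log units; that floor lies within the scatter).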

Compound 4, half-maximal effective concentration: 20 nM
Compound 4: the middle estimate sits 150-fold (2.18 log units) above what was measured; the whole stated range lies above it.
By their numbers in this assay, from the lowest: compound 4; then compound 3; then compound 2. At a limit, above all of these: compound 1.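

In this assay, putting 3-carboxy-4-hydroxyphenyl in place of 4-chloro-2-fluorophenyl on the shared core gives an at least 250-fold lower number from compound 1 to compound 4 (2.39 log units; beyond the scatter), so a change at this one position, on an aromatic carbon meta to a large group, is enough to produce a very large step. The earlier compounds shown here could not show this, as compound 2 and compound 3 are built on a different core and offered no step that isolates this position. The size given is only a floor, and the real step may be larger, because compound 1 gives a limit rather than a number: the limit of > 5000 nM in this assay, at which 1 of the 4 values shown sits.

It remains open whether the carboxy group, the hydroxy group or the two together account for the step, since the outer ring of compound 4 brings both at once and the compounds shown do not separate them on this core. From the compounds shown here alone, it is also open whether a methyl ester or a tetrazole in place of the carboxy group, or a methoxy group in place of the hydroxy group, would keep the value near compound 4 and its 20 nM or move it away.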